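Swapping Amino for Formyl on a Fluorinated Nucleoside

The source may report more compounds than this note shows. Statements on the series, on what has been measured and on what is new or still open speak of the compounds shown alone.

- Compound 1 `O=Cc1cc(=O)[nH]c(=O)n1[C@@H]1O[C@H](CO)[C@@H](O)[C@H]1O`: > 50000 nM (a limit)
- Compound 2 `[N-]=[N+]=Nc1c(F)c(=O)[nH]c(=O)n1[C@@H]1O[C@H](CO)[C@@H](O)[C@H]1O`: 1800 nM
- Compound 3 `Nc1c(F)c(=O)[nH]c(=O)n1[C@@H]1O[C@H](CO)[C@@H](O)[C@H]1O`: 2600 nM

All of these values come from a functional assay on MDA-MB-468 cells (Homo sapiens) for antiproliferative activity, read by WST assay, with a stated time of 3 days; a higher number here means a weaker inhibitor, a lower number a stronger inhibitor. Compound 3 stands level with compound 2, as the step between them shows: a 1.4-fold higher number from compound 2 to compound 3 (0.16 log units; within the scatter). The next change is formyl in place of amino on an aromatic carbon, and it gives compound 4 `O=Cc1c(F)c(=O)[nH]c(=O)n1[C@@H]1O[C@H](CO)[C@@H](O)[C@H]1O`. That one measured step was small, but it involved a different entering group, so it guides only weakly. Compound 1 also carries a formyl group but lacks the fluoro group, and its > 50000 nM is a limit of the assay. A move to a higher number therefore seems likely, though uncertain. The expected change is a 3.1-fold higher number from compound 3 to compound 4 (0.49 log units; beyond the scatter). Compound 4 is estimated at 8000 nM, with an expected range of 1500 nM to 40000 nM.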

Compound 4, half-maximal inhibitory concentration: 1900 nM
For compound 4 the middle estimate is 4.2-fold (0.62 log units) above the measured one, within the range that was stated.
By their numbers in this assay, from the lowest: compounds 2, 4 and 3 (each within the scatter of the next). At a limit, above all of these: compound 1.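

Formyl, amino and azido are interchangeable at this position as far as this read-out can tell: a 1.4-fold lower number from compound 3 to compound 4 (0.14 log units; within the scatter) and a 1.1-fold higher number from compound 2 to compound 4 (0.02 log units; within the scatter). With the formyl group held constant, fluoro in place of hydrogen makes a large difference, an at least 26-fold lower number from compound 1 to compound 4 (1.42 log units; beyond the scatter), so here the fluoro group matters far more than the group swapped beside it in these compounds. The value of compound 1 is a limit, so the true size of that step remains unknown: the limit of > 50000 nM in this assay, at which 1 of the 4 values shown sits.

As far as these compounds go, whether a carboxylic acid or a longer chain in place of the formyl group would stay at this level remains open. So does whether chloro could stand in for fluoro.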